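Replacing the sulfur-bearing group of compound 3

The compounds below may be only part of what the source reports. "The series", "measured", "known", "first", "only" and "open" are said of these compounds alone.

In a functional assay on the whole organism with Canis familiaris (Canis lupus familiaris) as the target (on this read-out higher numbers stand for an effect only at larger amounts of compound and lower numbers for an effect already at smaller amounts), compound 1 (`OC(CSc1[nH]cnc2ncnc1-2)CN1CCN(C(c2ccc(Cl)cc2)c2ccc(Cl)cc2)CC1`) gives 0.33 mg/kg and compound 2 (`OC(CSc1[nH]cnc2ncnc1-2)CN1CCN(C(c2ccc(Br)cc2)c2ccc(Br)cc2)CC1`) gives 0.31 mg/kg within the scatter of each other. Compound 3 (`Nc1nc(SCC(O)CN2CCN(C(c3ccc(F)cc3)c3ccc(F)cc3)CC2)c2[nH]cnc2n1`) gives 0.85 mg/kg as the highest of the three numbers, beyond the scatter from both others. Compound 4 (`CN(CC(O)CN1CCN(C(c2ccc(F)cc2)c2ccc(F)cc2)CC1)c1[nH]cnc2ncnc1-2`) differs from compound 3 by a group of 11 heavy atoms (6 carbon, 5 nitrogen; one five-membered aromatic ring with 2 hetero atoms, one six-membered aromatic ring with 2 hetero atoms) in place of a group of 11 heavy atoms (5 carbon, 5 nitrogen, 1 sulfur; one five-membered aromatic ring with 2 hetero atoms, one six-membered aromatic ring with 2 hetero atoms), on a saturated chain carbon, two bonds along the chain from an oxygen on a saturated carbon on a saturated chain carbon, two bonds along the chain from an oxygen on a saturated carbon. Within the data shown here, no measured pair isolates this change, so direct guidance is lacking. In this assay a small move toward a higher number is expected, possibly none beyond the scatter. The estimated step of a 1.4-fold higher number from compound 3 to compound 4 (0.15 log units; within the scatter) is expected to stay modest. For compound 4 the expected value is 1.2 mg/kg with 0.4 mg/kg as the estimated lower end and 3.5 mg/kg as the upper end of the range.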

Compound 4, dose for half-maximal effect: 0.74 mg/kg
The estimate for compound 4 lay 1.6-fold (0.21 log units) above the measured number; low and high end bracket the measured number.
By their numbers in this assay, from the lowest: compounds 2 and 1 (each within the scatter of the next); then compounds 4 and 3 (each within the scatter of the next).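

In this assay, the first pair differing in one place gives a 1.1-fold lower number from compound 3 to compound 4 (0.06 log units; within the scatter). At this saturated chain carbon, a group with 1 hydrogen-bond donor and 4 hydrogen-bond acceptors can therefore stand in place of one with 2 donors and 5 acceptors, and the sulfur-containing group is not required for a read-out within the scatter of compound 3. No supporting data explain this outcome.

Still open, going by these compounds, is how an amine, a carboxylic acid or a longer chain at this carbon would read out.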